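Chloro for methoxy on the salicylamide ring

The source may hold more compounds than are shown below. What is called first, only, known or untested is meant among the compounds shown, and "the series" means these compounds.

Compound 2 `COc1ccc(C(=O)Nc2ccc(C#N)cc2)c(O)c1` was examined in a functional assay on KG-1 cells (Homo sapiens) for cytotoxicity, read by luminescence and CellTiter-Glo, with a stated time of 3 days (on this read-out higher numbers stand for weaker inhibition and lower numbers for stronger inhibition), and gave 5430 nM. Among the two numbers shown, compound 2 stands highest, and its nearest neighbour is compound 1 `N#Cc1ccc(NC(=O)c2ccc(F)cc2O)cc1`, which in this assay gave 3150 nM. Within the data shown here, the only step between measured compounds that differ in one place is a 1.7-fold higher number from compound 1 to compound 2 (0.24 log units; within the scatter), a change that stays within the scatter of the method.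

Compound 3 `N#Cc1ccc(NC(=O)c2ccc(Cl)cc2O)cc1` has not yet been measured. It differs from compound 2 by chloro in place of methoxy on an aromatic carbon. Among the measured compounds shown here, the one step that bears on this change is the one from compound 1 to compound 2, in which a fluoro was exchanged for the same methoxy at the same aromatic carbon and the number moved only within the scatter. Since chloro, like fluoro, is a halogen entering in place of the methoxy, no step beyond the scatter is expected in this assay, with at most a slight drift toward the lower number of compound 1, so the step from compound 2 to compound 3 is estimated at a 1.5-fold lower number from compound 2 to compound 3 (0.18 log units; within the scatter). Compound 3 is therefore expected to give about 3600 nM, within a range of 1500 nM to 8500 nM.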

Compound 3, half-maximal inhibitory concentration: 1920 nM
Compound 3: middle estimate off by 1.9-fold (0.27 log units), on the high side, and the stated range covers the measured number.
By their numbers in this assay, from the lowest: compounds 3, 1 and 2 (each within the scatter of the next, the first and the last beyond it).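

Among these compounds, at this position, meta to a hydroxy group and para to a large group, the exchange of methoxy for chloro gives the first step that passes beyond the scatter in this assay, with a 2.8-fold lower number from compound 2 to compound 3 (0.45 log units; beyond the scatter) being a modest change. The two halogens, however, cannot be told apart in this assay, since a 1.6-fold lower number from compound 1 to compound 3 (0.22 log units; within the scatter) remains within the scatter, so the result gives no order between chloro and fluoro; of the two, only chloro is separated from methoxy by more than the scatter, while the fluoro compound 1 is not. Nothing available on these compounds accounts for the step from methoxy to chloro.

The compounds shown leave open how a bromo group, a methyl group or an amine at this aromatic carbon would stand against chloro in this cytotoxicity read-out. They also leave open whether the step from methoxy to chloro would persist if the nitrile of the shared core gave way to a carboxylic acid, as all three compounds carry the same nitrile and differ at this one place only.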